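Benzyl in place of propyl on the aromatic nitrogen

The compounds below may be only part of what the source reports. "The series", "measured", "known", "first", "only" and "open" are said of these compounds alone.

Of the compounds shown here, two sharing a core have been measured in an assay on isolated protein for inhibition of Gonadotropin-releasing hormone receptor (Rattus norvegicus); a higher number here means a weaker inhibitor, a lower number a stronger inhibitor. Compound 1 `COc1ccc(C#N)cc1CSc1nc2cc(NC(=O)C3CC3)ccc2n1C(C)C` carries a nitrile and an amide of a three-membered ring; in this assay compound 1 gives > 10000 nM, which is a limit of the assay and not a number. Compound 2 `CCCn1c(SCc2cc([N+](=O)[O-])ccc2OC)nc2cc(NC(=O)NC(C)(C)C)ccc21` carries a nitro group and a tert-butylurea instead; in this assay compound 2 gives 120 nM. Among the compounds with values here, compound 2 thus stands at the only numeric value so far, with the other result being a limit (the limit of > 10000 nM in this assay, at which 1 of the 2 values shown sits). Compound 3 `COc1ccc([N+](=O)[O-])cc1CSc1nc2cc(NC(=O)NC(C)(C)C)ccc2n1Cc1ccccc1` keeps the nitro group and the tert-butylurea of compound 2 and differs in one place: phenyl in place of ethyl on a saturated chain carbon bound to an aromatic nitrogen, which, cut one bond further out, reads propyl to benzyl. Within the data shown here, no measured step describes this exchange, so its effect must be estimated from compound 2 alone. The larger group on the saturated chain carbon is expected to keep compound 3 within reach of compound 2 or to move it somewhat toward stronger inhibition, a step of a 1.5-fold lower number from compound 2 to compound 3 (0.18 log units; within the scatter). Compound 3 is therefore estimated at 80 nM, with a range from 25 nM to 300 nM.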

Compound 3, half-maximal inhibitory concentration: 160 nM
The estimate for compound 3 lay 2.0-fold (0.30 log units) below the measured number; the measured number falls inside the stated range.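

In this assay, phenyl in place of ethyl on a saturated chain carbon bound to an aromatic nitrogen gives a 1.3-fold higher number from compound 2 to compound 3 (0.12 log units; within the scatter), so propyl and benzyl cannot be told apart at this position. Within the data shown here, this is the only reading of a single change so far, and it shows that the position accepts an aromatic ring of six carbons in place of an open chain without a difference that exceeds the scatter; compound 1 differs from compound 2 in more than one place, and its result is a limit of the assay, so it could not show this. Nothing at hand bears on why the two compounds read alike.

The compounds shown leave open whether a longer chain, or an amine or a carboxylic acid carried on the chain at this position, would read the same way. They also leave open whether propyl and benzyl would still read alike with something other than the nitro group and the tert-butylurea elsewhere on the molecule, since this step has been seen with that one pair of groups only.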